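Exchanging a thiazole for a methylfuran on the shared core

This account rests on a few compounds, and the source may have more. Where it says the series, first, only, none or still open, it means among the compounds named here.

Of the compounds shown here, three sharing one core have been measured in a functional assay for activation of Alpha-1B adrenergic receptor (Homo sapiens), read by calcium flux; on this read-out lower numbers stand for an effect already at smaller amounts and higher numbers for an effect only at larger amounts of compound. Compound 1 `c1cncc(-c2ccccc2OCC2=NCCN2)c1` gives 79.4 nM, compound 2 `c1c[nH]c(-c2ccccc2OCC2=NCCN2)c1` gives 1 nM, and compound 3 `c1ccc(-c2nccs2)c(OCC2=NCCN2)c1` gives 20 nM. Compound 3 therefore stands second highest of the three numbers, with a 4.0-fold lower number from compound 1 to compound 3 (0.60 log units; beyond the scatter) on one side and a 20-fold higher number from compound 2 to compound 3 (1.30 log units; beyond the scatter) on the other.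

Compound 4 `Cc1ccoc1-c1ccccc1OCC1=NCCN1` differs from compound 3 in one place: 3-methylfuran-2-yl in place of 1,3-thiazol-2-yl on an aromatic carbon. Among the measured compounds shown here, the steps that bear on this change are those that swap the ring attached at the same aromatic carbon. The swap to a 1,3-thiazol-2-yl gave a 4.0-fold lower number from compound 1 to compound 3 (0.60 log units; beyond the scatter), while the swap to a 1H-pyrrol-2-yl gave a 79-fold lower number from compound 1 to compound 2 (1.90 log units; beyond the scatter) and, seen from compound 3, a 20-fold higher number from compound 2 to compound 3 (1.30 log units; beyond the scatter). Rings attached through a five-membered aromatic carbon have so far given the lower numbers. Compound 4 is therefore expected to show a lower number than compound 3, a step estimated at a 4.0-fold lower number from compound 3 to compound 4 (0.60 log units; beyond the scatter). The estimate for compound 4 is 5 nM, within a range of 1 nM to 30 nM.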

Compound 4, half-maximal effective concentration: < 100000 nM
Compound 4 gave a limit, no number; the forecaster's own chance of this, stated with the estimate: 2%; the middle value lies beyond the limit too.
By their numbers in this assay, from the lowest: compound 2; then compound 3; then compound 1.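

In this assay compound 4 gives < 100000 nM, which is a limit and not a number. The steps to compound 4 from compound 1, compound 2 and compound 3 cannot be read. The compounds shown leave open where compound 4 stands among these three.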